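The source may hold more compounds than are shown below. What is called first, only, known or untested is meant among the compounds shown, and "the series" means these compounds.

Measured compounds:
compound 1, `O=C1O[C@@H](CN2CCCCC2)CN1c1ccc(-n2cc(-c3ccccn3)cn2)c(F)c1`: 3.1
compound 2, `CC(=O)OC[C@H]1CN(c2ccc(-n3cc(-c4ccccn4)cn3)c(F)c2)C(=O)O1`: 2.09
compound 3, `O=C1O[C@@H](CSc2cccs2)CN1c1ccc(-n2cc(-c3ccccn3)cn2)c(F)c1`: 4.29

All three share one core and differ only in the group carried on a saturated chain carbon bound to a saturated ring carbon. In a physicochemical assay for lipophilicity, read by HPLC, measured as octanol-water partition (on this read-out higher numbers stand for higher lipophilicity and lower numbers for lower lipophilicity), compound 1 stands second highest of the three numbers: compound 2 lies a number 1.01 log units lower from compound 1 to compound 2 (beyond the scatter), compound 3 lies a number 1.19 log units higher from compound 1 to compound 3 (beyond the scatter), and between those two there is a number 2.20 log units higher from compound 2 to compound 3 (beyond the scatter). Each of these steps is beyond the scatter, so the choice of this one group moves the read-out strongly in both directions.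

Compound 4, `CN(C)S(=O)(=O)NC[C@H]1CN(c2ccc(-n3cc(-c4ccccn4)cn3)c(F)c2)C(=O)O1`, is not yet measured. It differs from compound 1 in one place: (dimethylsulfamoyl)amino in place of piperidin-1-yl on a saturated chain carbon bound to a saturated ring carbon. The step from compound 1 to compound 2 is the closest guide, since there too a ring with one nitrogen gives way to a chain group carrying oxygen and hydrogen-bond acceptors, and that step lowered this assay by a large amount. For compound 4 a step of similar sign is therefore expected, a number 1.10 log units lower from compound 1 to compound 4 (beyond the scatter), giving an estimate of 2 with a range from 1.4 to 2.6.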

Compound 4, partition coefficient: 1.38
For compound 4 the middle estimate is 0.62 log units above the measured one; measured number below the stated range.
By their numbers in this assay, from the lowest: compound 4; then compound 2; then compound 1; then compound 3.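

In this assay, putting (dimethylsulfamoyl)amino in place of piperidin-1-yl on a saturated chain carbon bound to a saturated ring carbon gives a number 1.72 log units lower from compound 1 to compound 4 (beyond the scatter) and shows that this position can go lower than acetoxy took it. Exchanging acetoxy for (dimethylsulfamoyl)amino still gives a number 0.71 log units lower from compound 2 to compound 4 (beyond the scatter) as a further step down, and the span of the series now runs to a number 2.91 log units lower from compound 3 to compound 4 (beyond the scatter) between its two extremes. No measurement at hand offers a reason for this order.

The entering group differs from piperidin-1-yl in several ways at once, so its hydrogen-bond donor cannot be separated from its sulfur and oxygen atoms. Going by these compounds, whether a smaller acetamido group or a carboxylic acid at this place would fall higher or lower remains open.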